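The source may report more compounds than this note shows. Statements on the series, on what has been measured and on what is new or still open speak of the compounds shown alone.

In an ADME assay on MDBK cells (Bos taurus) for cytotoxicity, read by MTT assay, with a stated time of 96 h (on this read-out higher numbers stand for lower toxicity in this test and lower numbers for higher toxicity in this test), compound 1 `O=C(NC(=S)Nc1cccc(C(F)(F)F)c1)c1ccccc1` gives > 100000 nM, which is a limit of the assay and not a number. Compound 2 `CC[C@H]1CC[C@H](c2ccc(NC(=S)Nc3cccc(C(F)(F)F)c3)cc2)CC1` gives 9000 nM and compound 3 `FC(F)(F)c1cccc(NC(=S)Nc2ccc(Cl)cc2)c1` gives 17000 nM, and these two values lie within the scatter of each other. Compound 3 therefore stands level with compound 2 on the numbers available.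

Compound 4 `CCCC[C@H]1CC[C@H](c2ccc(NC(=S)Nc3cccc(C(F)(F)F)c3)cc2)CC1` carries 4-butylcyclohexyl in place of the chloro of compound 3 on an aromatic carbon (4-butylcyclohexyl in place of chloro on an aromatic carbon). For the measured compounds named here, the one measured step that bears on this change is a 1.9-fold higher number from compound 2 to compound 3 (0.28 log units; within the scatter), which swaps chloro for 4-ethylcyclohexyl in the opposite direction and stays within the scatter. The closest measured analogue is compound 2 at 9000 nM, so no step beyond the scatter is expected in this assay, though a drift towards a lower number is likely. The expected change is a 1.9-fold lower number from compound 3 to compound 4 (0.28 log units; within the scatter). Compound 4 is estimated at 9000 nM, with an expected range of 4000 nM to 20000 nM.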

Compound 4, half-maximal cytotoxic concentration: 10000 nM
Compound 4: the middle estimate sits 1.1-fold (0.05 log units) below what was measured; low and high end bracket the measured number.
By their numbers in this assay, from the lowest: compounds 2, 4 and 3 (each within the scatter of the next). At a limit, above all of these: compound 1.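

In this assay, a second large group on this aromatic carbon is now set against chloro, with 4-butylcyclohexyl in its place giving a 1.7-fold lower number from compound 3 to compound 4 (0.23 log units; within the scatter). For the compounds shown here, the first reading on the chain of the cyclohexyl group, ethyl in place of hydrogen on a saturated chain carbon, gives a 1.1-fold higher number from compound 2 to compound 4 (0.05 log units; within the scatter), so 4-ethylcyclohexyl and 4-butylcyclohexyl are not separated in this assay. Compound 1 remains the only compound held at a limit, which is not a number: the limit of > 100000 nM in this assay, at which 1 of the 4 values shown sits.

On these data alone, whether an amine or a carboxylic acid on this aromatic carbon, or a chain longer than butyl on the cyclohexyl ring, would give a step beyond the scatter stays open. As far as these compounds go, compound 1 differs from the other compounds in more than one place, so what separates it from them also stays open.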